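A few compounds are considered here, and "the series" means these few. Any claim that something is new, unique, unknown or untested is made for them only; others in the source may bear on it.

The account concerns two measured compounds and a third not yet measured. Compound 1 `CCCc1nc(-c2ccccc2)c(CNCCCN2CCN(c3cccc(Cl)c3)CC2)o1` was tested in an assay on HEK293 cells for inhibition of Voltage-dependent T-type calcium channel subunit alpha-1G (Homo sapiens), read by patch clamp (on this read-out lower numbers stand for stronger inhibition and higher numbers for weaker inhibition), and there compound 1 gives 1750 nM. Compound 2 `CCCc1nc(-c2ccccc2)c(CNCCN2CCN(c3ccc(C(F)(F)F)cc3)CC2)o1`, in this assay, gives 1300 nM. These two numbers lie within the usual scatter of one another, so the data place compound 1 on a par with compound 2 rather than apart from it. Compound 3 `CCCc1nc(-c2ccccc2)c(CNCCCN2CCN(c3ccccc3C)CC2)o1` is not yet measured. It differs from compound 1 in one place: 2-methylphenyl in place of 3-chlorophenyl on an amine nitrogen in a ring. Within the data shown here, no measured pair shows what such a change does here, and no trend among the measured compounds can be drawn on. Without such a comparison, the step is expected to be small, estimated as a 1.0-fold higher number from compound 1 to compound 3 (0.01 log units; within the scatter), not reaching beyond the scatter by much in either direction. Compound 3 is therefore expected to give 1800 nM in this assay, with a range from 700 nM to 4500 nM.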

Compound 3, half-maximal inhibitory concentration: 8750 nM
Compound 3: middle estimate off by 4.9-fold (0.69 log units), on the low side; the whole stated range lies below it.
By their numbers in this assay, from the lowest: compounds 2 and 1 (each within the scatter of the next); then compound 3.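

In this assay, among these compounds, this is the first pair differing in one place, and it shows that the group on the amine nitrogen in the ring can shift the read-out: 2-methylphenyl in place of 3-chlorophenyl gives a 5.0-fold higher number from compound 1 to compound 3 (0.70 log units; beyond the scatter), a step beyond the scatter. This step appears even though the two groups have the same number of heavy atoms, each has one six-membered aromatic ring of carbon only, and neither has hydrogen-bond donors, hydrogen-bond acceptors or a net charge. Nothing available gives a reason for the step.

Still open, going by these compounds, is whether the step follows the change from chlorine to methyl or the change in where that group sits, which a 2-chlorophenyl or 3-methylphenyl group on the same nitrogen could separate. On these data alone, it is also open where a plain phenyl group there would fall relative to compound 1 and compound 3.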